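The source may hold more compounds than are shown below. What is called first, only, known or untested is meant among the compounds shown, and "the series" means these compounds.

Measured in a functional assay on MIA PaCa-2 cells (Homo sapiens) for cytotoxicity, read by MTT assay, with a stated time of 4 h; on this read-out higher numbers stand for weaker inhibition and lower numbers for stronger inhibition:
- compound 1 `COC1=CC(=O)c2c(c(COc3c(F)cc(F)cc3F)c(C)n2C)C1=O`: 427 nM
- compound 2 `COC1=CC(=O)c2c(COc3ccc([N+](=O)[O-])cc3)c(C)n(C)c2C1=O`: 638 nM
- compound 3 `COC1=CC(=O)c2c(COc3ccccc3)c(C)n(C)c2C1=O`: 4560 nM

In this assay compound 3 gives 4560 nM, the highest number of the three and so the weakest inhibition. Compound 4 `COC1=CC(=O)c2c(COc3ccc(N)cc3)c(C)n(C)c2C1=O` differs from compound 3 by amino in place of hydrogen on an aromatic carbon. Within the data shown here, only one measured step bears on this change: a 7.1-fold higher number from compound 2 to compound 3 (0.85 log units; beyond the scatter), with hydrogen in place of nitro. Nitro and amino are different groups, and no measured compound carries amino, so that step sets no size or direction here. The expected step is therefore small, a 1.1-fold higher number from compound 3 to compound 4 (0.04 log units; within the scatter). For compound 4 the estimated value is 5000 nM, with an expected range from 1800 nM to 14000 nM.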

Compound 4, half-maximal inhibitory concentration: 504 nM
Compound 4: middle estimate off by 9.9-fold (1.00 log units), on the high side; the measured number lies below the stated range.
By their numbers in this assay, from the lowest: compounds 1, 4 and 2 (each within the scatter of the next); then compound 3.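

Changing phenoxy to 4-aminophenoxy gives a 9.0-fold lower number from compound 3 to compound 4 (0.96 log units; beyond the scatter) in this assay, so this ring place responds to amino as well as to nitro. Replacing nitro with amino gives a 1.3-fold lower number from compound 2 to compound 4 (0.10 log units; within the scatter), so this assay does not separate these two different groups here. Nothing measured here explains why they give such similar numbers.

As far as these compounds go, whether a methoxy group, a carboxylic acid or a dimethylamino group at this place would also lower the number remains open. So does the effect of amino at other places on this ring.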